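A few compounds are considered here, and "the series" means these few. Any claim that something is new, unique, unknown or untested is made for them only; others in the source may bear on it.

Compound 1, `O=[N+]([O-])c1cccc(CNc2cc(Br)cc3[nH]ncc23)c1`, gives 72%.
Compound 2, `O=[N+]([O-])c1cccc(CNc2cc(C(F)(F)F)cc3[nH]ncc23)c1`, gives 45%.
Compound 3, `O=[N+]([O-])c1ccc(CNc2cc(Br)cc3[nH]ncc23)cc1`, gives 63%.

All three numbers come from an assay for inhibition of Indoleamine 2,3-dioxygenase 1 (Homo sapiens), with stated times of 10 min and 60 min, tested at 10 uM; a higher number here means a stronger effect of the compound at the concentration tested, a lower number a weaker effect. Compound 1 and compound 2 share the same core and differ in one place: trifluoromethyl in place of bromo on an aromatic carbon. That change made the step of a number 27 percentage points lower from compound 1 to compound 2 (beyond the scatter), a drop beyond the usual scatter of this assay.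

Compound 3 carries the same atoms as compound 1, joined differently; the difference between the two cores is not broken down here. In this assay compound 3 and compound 1 lie within the scatter of each other, so nothing separates them. Compound 3 stands above compound 2 by more than the scatter.

Compound 4, `O=[N+]([O-])c1ccc(CNc2cc(C(F)(F)F)cc3[nH]ncc23)cc1`, has not yet been measured. It is made from compound 3 by the same change: trifluoromethyl in place of bromo on an aromatic carbon. The place is the same, word for word, as in the pair of compound 1 and compound 2, so this is the same change, seen a second time.

For the measured compounds named here, the only guide is the one measured step. The expectation is that compound 4 loses about as much as compound 2 did, an estimated step of a number 27 percentage points lower from compound 3 to compound 4 (beyond the scatter) beside the earlier one, because compound 1 to compound 2 gave a number 27 percentage points lower from compound 1 to compound 2 (beyond the scatter). The read-out for compound 4 in this assay is therefore estimated at 36%, expected to lie between 20% and 52%.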

Compound 4, a percentage reported as inhibition, at one concentration (the size of the read-out at that concentration, not a potency): 52%
For compound 4 the middle estimate is 16 percentage points below the measured one; measured number inside the range.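

In this assay, putting trifluoromethyl in place of bromo on the core of compound 3 again lowers the read-out, with a number 11 percentage points lower from compound 3 to compound 4 (beyond the scatter). For the compounds shown here, the direction of the change therefore carries over from one core to the other, but its size does not, and the two drops are clearly not the same: the same change on two cores in this assay, a number 27 percentage points lower (beyond the scatter) from compound 1 to compound 2 and a number 11 percentage points lower (beyond the scatter) from compound 3 to compound 4, 16 percentage points apart, beyond the scatter of two such steps With only two pairs, this shows that the loss on one core is a fair guide to its sign on the other but a poor guide to its size, and it does not show why the two cores, which carry the same atoms joined differently, respond by different amounts.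

The compounds shown leave open how a smaller halogen such as chloro, or a methyl, a nitrile or an amine, would read at the same place on either core, and whether the same change would still lower the read-out on a core with a carboxylic acid in place of the nitro group. They also leave open how these steps would look at other concentrations, since each number here is the size of the effect at a single concentration.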